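A smaller, ring-free amine on the shared core

A few compounds are considered here, and "the series" means these few. Any claim that something is new, unique, unknown or untested is made for them only; others in the source may bear on it.

Three measured compounds share one core and differ only in the group on a saturated chain carbon bound to an aromatic carbon. Compound 1 `COc1ccc(/C=C\c2cc(OC)c(OC)c(OC)c2)cc1OCc1ccc(CN2CC[C@H](C(=O)O)C2)cc1` carries 3-carboxypyrrolidin-1-yl there. In a functional assay on HeLa cells (Homo sapiens) for antiproliferative activity, read by CCK-8 assay, with a stated time of 48 h (on this read-out lower numbers stand for stronger inhibition and higher numbers for weaker inhibition), compound 1 reaches only the limit of the assay, > 10000 nM. Compound 2 `COc1ccc(/C=C\c2cc(OC)c(OC)c(OC)c2)cc1OCc1ccc(CN2CCCC[C@H]2C(=O)O)cc1` carries 2-carboxypiperidin-1-yl instead. In this assay compound 2 likewise stops at the limit, > 10000 nM. Compound 3 `COc1ccc(/C=C\c2cc(OC)c(OC)c(OC)c2)cc1OCc1ccc(CN2CC[C@@H](C(=O)O)C2)cc1` has the same atoms and bonds as compound 1 but the opposite configuration at its ring stereocentre, and in this assay compound 3 gives 12800 nM.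

Compound 2 therefore stands at the limit, where two of the three values shown sit (the limit of > 10000 nM in this assay, at which 2 of the 3 values shown sit). The steps between the measured compounds, a step that the two limits leave unreadable from compound 1 to compound 2, a step that the limit leaves unreadable from compound 1 to compound 3 and a step that the limit leaves unreadable from compound 2 to compound 3, are all unreadable, so none of them gives a size to build on; the pair of compounds 1 and 3 differ only in configuration as drawn (the fact that compounds 1 and 3 differ only in the configuration as drawn), and even that step stays hidden behind the limit.

Compound 4 `COc1ccc(/C=C\c2cc(OC)c(OC)c(OC)c2)cc1OCc1ccc(CNCCO)cc1` carries the change ((2-hydroxyethyl)amino in place of 2-carboxypiperidin-1-yl on a saturated chain carbon bound to an aromatic carbon). With no readable step to anchor it, the expectation is loosely held: compound 4 is expected to move toward stronger inhibition by an at least 3.3-fold lower number from compound 2 to compound 4 (0.52 log units; beyond the scatter). Compound 4 is estimated at 3000 nM, between 300 nM and 30000 nM.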

Compound 4, half-maximal inhibitory concentration: 4400 nM
Compound 4: the middle estimate sits 1.5-fold (0.17 log units) below what was measured; the range from low to high includes it.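

The position on a saturated chain carbon bound to an aromatic carbon now gives its first exact step in this assay: a 2.9-fold lower number from compound 3 to compound 4 (0.46 log units; beyond the scatter). Within the data shown here, replacing the other two ring groups with (2-hydroxyethyl)amino points the same way, with an at least 2.2-fold lower number from compound 2 to compound 4 (0.35 log units; beyond the scatter) and an at least 2.2-fold lower number from compound 1 to compound 4 (0.35 log units; beyond the scatter), and the steps among compounds 1, 2 and 3 themselves cannot be read, so compound 4 is the first sign that this position responds to a change at all. Those two further steps give only minimum sizes, as each starts from a limit and not from a number: the limit of > 10000 nM in this assay, at which 2 of the 4 values shown sit.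

The change from the rings to (2-hydroxyethyl)amino removes the ring and the carboxy group together, so the compounds shown cannot tell which of the two losses goes with the lower number. A ring without the acid, such as piperidin-1-yl, or a longer chain, such as (3-hydroxypropyl)amino, would pull these apart and would also show whether the hydroxyl of the entering chain matters.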